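Lengthening the chain of a sigma-1 ligand

This account rests on a few compounds, and the source may have more. Where it says the series, first, only, none or still open, it means among the compounds named here.

Compound 3 `CCN(CCCc1ccccc1)C1CCc2ccsc2CC1` gives 17 nM in an assay on membranes from brain for displacement of a labelled ligand from Sigma non-opioid intracellular receptor 1 (Cavia porcellus), read by scintillation counting, with a stated time of 120 min (on this read-out higher numbers stand for weaker inhibition and lower numbers for stronger inhibition), level at the digits shown with compound 2 `CN(CCCCc1ccccc1)C1CCc2ccsc2CC1`, which gives 17 nM; together these two are the lowest of the three numbers measured. Within the data shown here, compound 1 `c1ccc(CCCCNC2CCc3ccsc3CC2)cc1` gives 62 nM, and the only step among measured pairs that differ in one place, a 3.6-fold lower number from compound 1 to compound 2 (0.56 log units; beyond the scatter), concerns the amine nitrogen and not the chain. Compound 4 `CCN(CCCCc1ccccc1)C1CCc2ccsc2CC1` differs from compound 3 by benzyl in place of phenyl on a saturated chain carbon, three bonds along the chain from an amine nitrogen. Among the measured compounds shown here, no measured pair differs only in this way, so the step has no direct precedent. Compound 2 carries the same longer chain beside a methyl on the nitrogen and sits level with compound 3, which suggests the chain length itself shifts the number little. Compound 4 is therefore expected to give about 15 nM in this assay, between 6 nM and 40 nM, a step of a 1.1-fold lower number from compound 3 to compound 4 (0.05 log units; within the scatter) that is expected to stay within the scatter.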

Compound 4, inhibition constant: 12 nM
The estimate for compound 4 lay 1.3-fold (0.10 log units) above the measured number; the range from low to high includes it.
By their numbers in this assay, from the lowest: compounds 4, 2 and 3 (each within the scatter of the next); then compound 1.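

In this assay, the change of phenyl to benzyl on a saturated chain carbon, three bonds along the chain from an amine nitrogen, now has a direct reading: a 1.4-fold lower number from compound 3 to compound 4 (0.15 log units; within the scatter), so with ethyl on the nitrogen this chain change leaves the number within the scatter. Methyl in place of hydrogen on a saturated chain carbon bound to an amine nitrogen is equally small, with a 1.4-fold lower number from compound 2 to compound 4 (0.15 log units; within the scatter), whereas replacing hydrogen with ethyl on the nitrogen gives a 5.2-fold lower number from compound 1 to compound 4 (0.71 log units; beyond the scatter), so ethyl, like methyl, separates the number from that of the compound with hydrogen there. Nothing measured here explains the size of these steps.

As far as these compounds go, whether the benzyl change would behave the same way with hydrogen on the nitrogen remains open. So does the effect of a longer chain or of propyl on the amine nitrogen.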